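This account rests on a few compounds, and the source may have more. Where it says the series, first, only, none or still open, it means among the compounds named here.

Compound 1 `COc1cc(C(=O)c2sc(N(C)C)nc2N)cc(OC)c1OC`: "not determined" (no result reported)
Compound 2 `COc1cc(C(=O)c2sc(N3CCCC3)nc2N)cc(OC)c1OC`: 260 nM

Going by the values given here, in a functional assay on MOLT-4 cells (Homo sapiens) for antiproliferative activity, read by cell counting, with a stated time of 2 days (on this read-out higher numbers stand for weaker inhibition and lower numbers for stronger inhibition), compound 2 gives 260 nM, the only number available, so it cannot yet be ranked against any other compound. Compound 3 `COc1cc(C(=O)c2sc(N3CCCCC3)nc2N)cc(OC)c1OC` keeps the shared core and changes one group: piperidin-1-yl in place of pyrrolidin-1-yl on an aromatic carbon. Among the compounds with values here, no measured step exists to size this change, and the expectation rests on compound 2 alone. A small loss of inhibition in this assay is expected, within the usual scatter or close to it. The expected step is a 1.8-fold higher number from compound 2 to compound 3 (0.27 log units; within the scatter). For compound 3 the estimated value is 480 nM, with an expected range of 150 nM to 1800 nM.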

Compound 3, half-maximal inhibitory concentration: 16000 nM
For compound 3 the middle estimate is 33-fold (1.52 log units) below the measured one; measured number above the stated range.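

In this assay, this position on the aromatic carbon tolerates little change: piperidin-1-yl in place of pyrrolidin-1-yl gives a 62-fold higher number from compound 2 to compound 3 (1.79 log units; beyond the scatter). A single ring enlargement is therefore enough to move the number far beyond the scatter, so ring size at this site matters in this series, at least for these two compounds. No measured evidence accounts for the loss.

Compound 1 has no number, so the open-chain amine cannot be placed against either ring. As far as these compounds go, whether azetidin-1-yl or morpholin-4-yl at this position would keep the level of compound 2 remains open.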